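Sulfonyl substituent swap in a cyanotetrahydroquinoline sulfonamide series

The source may hold more compounds than are shown below. What is called first, only, known or untested is meant among the compounds shown, and "the series" means these compounds.

Measured so far:
compound 1 `Cn1cncc1CN1CC(N(CCn2cccc2)S(=O)(=O)c2ccccn2)Cc2cc(C#N)ccc21` gives 12.4 10^-6 cm/s
compound 2 `CC(=O)N1CCC(CN(C2Cc3cc(C#N)ccc3N(Cc3cncn3C)C2)S(=O)(=O)c2ccccn2)CC1` gives 0.5 10^-6 cm/s

In an ADME assay on Caco-2 cells (Homo sapiens) for permeability, in the apical to basolateral direction (a higher number here means that the compound crosses the layer faster, a lower number that the compound crosses the layer more slowly), compound 1 holds the highest of the two numbers; its nearest neighbour is compound 2, reached by a 25-fold lower number from compound 1 to compound 2 (1.39 log units; beyond the scatter), a large step well beyond the scatter.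

Compound 3 `Cn1cnc(S(=O)(=O)N(CCn2cccc2)C2Cc3cc(C#N)ccc3N(Cc3cncn3C)C2)c1` is not yet measured. It differs from compound 1 in one place: 1-methyl-1H-imidazol-4-yl in place of pyridin-2-yl on a sulfonyl sulfur. Cut one bond further out, this reads (pyridin-2-yl)sulfonyl to (1-methyl-1H-imidazol-4-yl)sulfonyl.

Going by the values given here, no measured step touches the sulfonyl sulfur. Among the compounds with values here, the only step available, from compound 1 to compound 2, changes the group on the saturated chain carbon bound to the sulfonamide nitrogen, a different place, so it gives no direct reading of what the present change will do. What remains is the count itself: a six-membered aromatic ring with one hetero atom and one hydrogen-bond acceptor leaves, a five-membered aromatic ring with two hetero atoms and two hydrogen-bond acceptors enters, at equal heavy-atom count and with no change in charge or donors.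

On that basis a modest lowering is expected, a 2.1-fold lower number from compound 1 to compound 3 (0.32 log units; beyond the scatter), with wide uncertainty. Compound 3 is estimated at 6 10^-6 cm/s, within the range 2 10^-6 cm/s to 15 10^-6 cm/s.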

Compound 3, apparent permeability: 0.3 10^-6 cm/s
For compound 3 the middle estimate is 20-fold (1.30 log units) above the measured one, outside the stated range (below it).
By their numbers in this assay, from the lowest: compounds 3 and 2 (each within the scatter of the next); then compound 1.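

In this assay, 1-methyl-1H-imidazol-4-yl in place of pyridin-2-yl on a sulfonyl sulfur gives a 41-fold lower number from compound 1 to compound 3 (1.62 log units; beyond the scatter), so the sulfonyl substituent, untouched by the earlier step, is also a place where one change produces a large step. The exchange leaves the heavy-atom count, the net charge and the hydrogen-bond donors as they were; what the count shows as different is a five-membered aromatic ring with 2 hetero atoms and 2 hydrogen-bond acceptors for a six-membered one with 1 hetero atom and 1 hydrogen-bond acceptor, so a large step here does not require any difference in those unchanged counts. No measurement at hand bears on why the step is this large.

With a single pair at this place, the ring size, the second ring nitrogen and the methyl group cannot be told apart as the feature that matters. Going by these compounds, it remains open how phenyl or 1-methyl-1H-pyrazol-4-yl on the sulfonyl sulfur would read in this assay, and whether 1-methyl-1H-imidazol-4-yl behaves the same way alongside 1-acetylpiperidin-4-yl on the saturated chain carbon.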